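Trifluoromethyl in place of ethoxy on the aniline ring

The source may hold more compounds than are shown below. What is called first, only, known or untested is meant among the compounds shown, and "the series" means these compounds.

Measured compounds:
compound 1, `Fc1cccc(Nc2nc3nonc3nc2Nc2ccccc2F)c1`, 190 nM
compound 2, `COc1cccc(Nc2nc3nonc3nc2Nc2ccccc2F)c1`, 830 nM
compound 3, `CCOc1cccc(Nc2nc3nonc3nc2Nc2ccccc2F)c1`, 2200 nM

In an assay on mitochondria from L6 cells (Rattus norvegicus) for activation, with a stated time of 90 min (a lower number here means that less compound is needed, a higher number that more compound is needed for the effect), compound 3 gives 2200 nM, the highest number of the three. Its nearest neighbour is compound 2, which gives 830 nM; the furthest is compound 1, which gives 190 nM. The measured steps run one way: a 4.4-fold higher number from compound 1 to compound 2 (0.64 log units; beyond the scatter), a 2.7-fold higher number from compound 2 to compound 3 (0.42 log units; beyond the scatter), and taken together a 12-fold higher number from compound 1 to compound 3 (1.06 log units; beyond the scatter).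

Compound 4, `Fc1ccccc1Nc1nc2nonc2nc1Nc1cccc(C(F)(F)F)c1`, differs from compound 3 by trifluoromethyl in place of ethoxy on an aromatic carbon. Among the measured compounds shown here, no measured step places a trifluoromethyl on this carbon, so the step has no direct precedent. What bears on it is that the ethoxy itself sits at the unfavourable end of the series, with the large step from compound 1 to compound 3 and the modest one from compound 2 to compound 3 both pointing to higher numbers as the alkoxy grew. Removing the ethoxy is therefore expected to bring the number down, though by less than the full return to compound 1, since the trifluoromethyl is a different group from fluoro. Compound 4 is estimated at 600 nM, between 180 nM and 2000 nM, an expected step of a 3.7-fold lower number from compound 3 to compound 4 (0.56 log units; beyond the scatter) in this assay.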

Compound 4, half-maximal effective concentration: < 1000 nM
Compound 4 ended at the assay's limit; the forecaster's own chance of this, stated with the estimate: 3%; the middle value lies beyond the limit too.
By their numbers in this assay, from the lowest: compound 1; then compound 2; then compound 3.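

In this assay compound 4 gives < 1000 nM as a limit of the assay and not as a number. Even so, the limit leaves an at least 2.2-fold lower number from compound 3 to compound 4 (0.34 log units; beyond the scatter) as a readable change, so on this aromatic carbon the number falls from the level of the ethoxy compound with a group that carries no oxygen. The earlier compounds shown here showed only fluoro, methoxy and ethoxy here, and trifluoromethyl now adds a group with more heavy atoms than ethoxy that still stands on the lower side of compound 3.

On these data alone, the steps from compound 1 and from compound 2 to compound 4 cannot be read, so the place of compound 4 relative to those two stays open. Also open, as far as these compounds go, is how a nitrile, an amine or a carboxylic acid would stand on this same carbon.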